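Swapping an arylsulfonyl for a morpholine sulfonamide

The source may hold more compounds than are shown below. What is called first, only, known or untested is meant among the compounds shown, and "the series" means these compounds.

Measured compounds:
- compound 1 `Cc1c(Cc2ccc(C(=O)O)cc2S(=O)(=O)c2ccccc2)c2c(n1CC(=O)O)CCNC2=O`: 19 nM
- compound 2 `Cc1c(Cc2cc(Br)ccc2S(=O)(=O)c2ccccc2)c2c(n1CC(=O)O)CCNC2=O`: 3.9 nM
- compound 3 `CNC(=O)c1cccc(S(=O)(=O)c2ccccc2Cc2c3c(n(CC(=O)O)c2C)CCNC3=O)c1`: 240 nM

Of the compounds shown here, three sharing one core have been tested in a functional assay on CHO.K1 cells for antagonist activity at prostaglandin D2 receptor 2 (Homo sapiens), read by GTPgammaS binding, with a stated time of 1 h; a higher number here means a weaker inhibitor, a lower number a stronger inhibitor. Compound 1 gives 19 nM in this assay, and compound 2 gives 3.9 nM. Compound 3, with 240 nM, carries the highest number of the three, beyond the scatter of both of the others, so it is the weakest inhibitor in this group.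

The next compound, compound 4 `Cc1c(Cc2ccccc2S(=O)(=O)N2CCOCC2)c2c(n1CC(=O)O)CCNC2=O`, differs from compound 3 in one place: morpholin-4-yl in place of 3-(methylcarbamoyl)phenyl on a sulfonyl sulfur. Among the measured compounds shown here, no measured pair shows this same change, so there is no direct precedent for its size or direction. Compounds 1 and 2 both keep an aryl group on the sulfonyl sulfur, whereas compound 4 keeps neither that aryl nor any group on the ring that bears the sulfonyl, and nothing here separates the two effects.

Compound 4 is therefore expected to stay near the number of compound 3, with a step of a 1.5-fold higher number from compound 3 to compound 4 (0.16 log units; within the scatter) that is not expected to reach beyond the scatter. The estimate for compound 4 in this assay is 350 nM, with a range from 70 nM to 1800 nM.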

Compound 4, half-maximal inhibitory concentration: 22 nM
Compound 4: middle estimate off by 16-fold (1.20 log units), on the high side; the whole stated range lies above it.
By their numbers in this assay, from the lowest: compound 2; then compounds 1 and 4 (each within the scatter of the next); then compound 3.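

On a sulfonyl sulfur whose other neighbour is an aromatic carbon, morpholin-4-yl in place of 3-(methylcarbamoyl)phenyl gives an 11-fold lower number from compound 3 to compound 4 (1.04 log units; beyond the scatter) in this assay, so this position responds strongly to the group it carries. An aromatic ring on the sulfonyl sulfur is not required for a low number, since compound 4, with its six-membered non-aromatic ring there, gives 22 nM. Nothing available explains the size of this step.

The change removes the aromatic ring and the methylcarbamoyl group together, so their separate contributions remain unresolved. As far as these compounds go, it also remains open how a piperidine or a dimethylamino group on the same sulfur would compare with morpholin-4-yl, and whether a morpholine sulfonamide would tolerate a bromine or a carboxylic acid on the ring that bears the sulfonyl.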